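This account rests on a few compounds, and the source may have more. Where it says the series, first, only, none or still open, it means among the compounds named here.

Three compounds here carry a measured number and a fourth awaits one. Compound 1 `CN(C)CCn1cnnc1-c1cc(Oc2ccc(NC(=O)N/N=C/c3cc(C(C)(C)C)cc(C(C)(C)C)c3O)cc2F)ccn1` in a functional assay on A549 cells (Homo sapiens) for cytotoxicity, read by MTT assay, with a stated time of 72 h (on this read-out lower numbers stand for stronger inhibition and higher numbers for weaker inhibition), gives 980 nM. Compound 3 `CN(C)CCn1cnnc1-c1cc(Oc2ccc(NC(=O)N/N=C/c3ccc(F)cc3F)cc2F)ccn1` in this assay gives 1870 nM, the larger of the two numbers shown, though it lies within the usual scatter of the value of compound 1, so the two cannot be separated on this read-out. Compound 2 `Cn1ncnc1-c1cc(Oc2ccc(NC(=O)N/N=C/c3ccccc3)cc2F)ccn1` in this assay gives only a limit, > 100000 nM, as set out by the limit of > 100000 nM in this assay, at which 1 of the 3 values shown sits. The unmeasured compound 4 `COc1ccc(/C=N/NC(=O)Nc2ccc(Oc3ccnc(-c4nncn4CCN(C)C)c3)c(F)c2)cc1O` departs from compound 3 in a single place: 3-hydroxy-4-methoxyphenyl in place of 2,4-difluorophenyl on a carbon with a double bond to nitrogen. Among the compounds with values here, no pair of measured compounds differs in just one place, so no measured step shows what such a swap does on its own. Given that the values of compound 1 and compound 3 sit within the scatter of each other, the change expected from compound 3 to compound 4 in this assay is none beyond the scatter, a 1.2-fold lower number from compound 3 to compound 4 (0.10 log units; within the scatter). Compound 4 is therefore estimated at 1500 nM, with a range from 400 nM to 6000 nM.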

Compound 4, half-maximal inhibitory concentration: > 100000 nM
Compound 4 gave a limit, no number; the forecaster's own chance of this, stated with the estimate: 10%; middle value at least 66-fold (1.82 log units) away from the limit.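

In this assay, the group on a carbon with a double bond to nitrogen proves decisive: 3-hydroxy-4-methoxyphenyl in place of 2,4-difluorophenyl gives an at least 53-fold higher number from compound 3 to compound 4 (1.72 log units; beyond the scatter). Within the data shown here, no earlier pair differed in just one place, so this is the first measured sign that a change at this position alone can shift the read-out this far. The value of compound 4 is a limit and not a number, so the step has a lower bound but no known full size: the limit of > 100000 nM in this assay, at which 2 of the 4 values shown sit.

The fluorines left together and the hydroxy and methoxy entered together, so which of these changes accounts for the step stays open. A phenyl carrying only a hydroxy, only a methoxy or an amine at this place would help to separate them.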